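From methyl to methoxy: expecting compound 3

The source may report more compounds than this note shows. Statements on the series, on what has been measured and on what is new or still open speak of the compounds shown alone.

Measured in an ADME assay on THP-1 cells (Homo sapiens) for cytotoxicity, read by flow cytometry and propidium iodide staining, with a stated time of 24 h; a higher number here means a weaker inhibitor, a lower number a stronger inhibitor:
Compound 1 `NS(=O)(=O)c1ccc(C[Te]c2ccccc2)cc1` gives 6370 nM
Compound 2 `Cc1ccc([Te]Cc2ccc(S(N)(=O)=O)cc2)cc1` gives > 25000 nM (a limit)

Compound 2 has no exact number, only the limit > 25000 nM. It stands at the limit of > 25000 nM in this assay, at which 1 of the 2 values shown sits. Compound 3 `COc1ccc([Te]Cc2ccc(S(N)(=O)=O)cc2)cc1` is still unmeasured and carries methoxy in place of methyl on an aromatic carbon. Among the measured compounds shown here, one measured step bears on this, an at least 3.9-fold higher number from compound 1 to compound 2 (0.59 log units; beyond the scatter), but it replaced hydrogen rather than methyl, so it only loosely guides the size. A modest step to a lower number, or none beyond the scatter, is expected in this assay. Compound 3 is estimated at 20000 nM, with an expected range of 9000 nM to 35000 nM. The estimate means an expected at least 1.2-fold lower number from compound 2 to compound 3 (0.09 log units; that floor lies within the scatter).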

Compound 3, half-maximal inhibitory concentration: 1980 nM
Compound 3: the middle estimate sits 10-fold (1.00 log units) above what was measured, outside the stated range (below it).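

In this assay, methoxy in place of methyl on this aromatic carbon gives an at least 12-fold lower number from compound 2 to compound 3 (1.10 log units; beyond the scatter), and methoxy in place of hydrogen gives a 3.2-fold lower number from compound 1 to compound 3 (0.51 log units; beyond the scatter). The position can therefore move the number both ways, since methyl raised it with an at least 3.9-fold higher number from compound 1 to compound 2 (0.59 log units; beyond the scatter) while methoxy lowers it. Compound 2 holds only a limit, so the step from methyl to methoxy is a floor: the limit of > 25000 nM in this assay, at which 1 of the 3 values shown sits.

The compounds shown leave open whether an amine, a hydroxyl or a longer ethoxy chain on this aromatic carbon would follow methoxy or methyl.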